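A Pyridine for a Phenyl Ring in Compound 3

The compounds below may be only part of what the source reports. "The series", "measured", "known", "first", "only" and "open" are said of these compounds alone.

In an ADME assay on Caco-2 cells (Homo sapiens) for permeability, read by LC-MS, in the apical to basolateral direction, with a stated time of 2 h (a lower number here means that the compound crosses the layer more slowly, a higher number that the compound crosses the layer faster), the entry for compound 1 `COc1cc(C(=O)N2CCCC2)cc2nc(NCc3cccc(Cl)c3)oc12` reads "not determined" (no result reported). For the measured compounds named here, compound 2 `COc1cc(C(=O)N2CCC(O)C(C)C2)cc2nc(NCc3cccc(Cl)c3)oc12`, at 84 nm/s, therefore holds the only number available, and nothing yet shows how it ranks. Compound 3 `COc1cc(C(=O)N2CCC(O)C(C)C2)cc2nc(NCc3cncc(Cl)c3)oc12` departs from compound 2 in one place: 5-chloropyridin-3-yl in place of 3-chlorophenyl on a saturated chain carbon bound to a nitrogen on an aromatic ring. Going by the values given here, no measured step exists to show how much such a change moves this assay. A small downward step, no larger than the usual scatter, is expected: a 1.4-fold lower number from compound 2 to compound 3 (0.15 log units; within the scatter). For compound 3 the estimated value is 60 nm/s, with an expected range from 25 nm/s to 130 nm/s.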

Compound 3, apparent permeability: 9.3 nm/s
Compound 3: middle estimate off by 6.5-fold (0.81 log units), on the high side; measured number outside the range, below it.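

In this assay, 5-chloropyridin-3-yl in place of 3-chlorophenyl on a saturated chain carbon bound to a nitrogen on an aromatic ring gives a 9.0-fold lower number from compound 2 to compound 3 (0.96 log units; beyond the scatter) and so shows that this position is not indifferent to the exchange. The heavy-atom count stays the same, and the entering ring has one hetero atom and one hydrogen-bond acceptor. Nothing at hand explains the size of this step. On these data alone, what a 3-fluorophenyl or a 5-methoxypyridin-3-yl would give at this place remains open. As far as these compounds go, whether the step would recur with another amide on the shared core is equally open.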